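A few compounds are considered here, and "the series" means these few. Any claim that something is new, unique, unknown or untested is made for them only; others in the source may bear on it.

Measured compounds in an assay on CHO cells for displacement of a labelled ligand from transient receptor potential cation channel subfamily V member 1 (Rattus norvegicus); a higher number here means a weaker inhibitor, a lower number a stronger inhibitor:

- compound 1, `Cc1ccc(CC(CNC(=O)C(C)(C)c2ccc(NS(C)(=O)=O)cc2)COC(=O)C(C)(C)C)cc1C`: 370 nM
- compound 2, `C[C@@H](C(=O)NC[C@H](COC(=O)C(C)(C)C)Cc1ccccc1)c1ccc(NS(C)(=O)=O)c(F)c1`: 298 nM
- compound 3, `Cc1ccc(CC(CNC(=O)C2(c3ccc(NS(C)(=O)=O)cc3)CC2)COC(=O)C(C)(C)C)cc1C`: 396 nM

In this assay compound 2 gives the lowest of the three numbers, but its gaps to compound 1 and to compound 3 both lie within the usual scatter, so the three measured compounds are not distinguished from one another by these data.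

The next compound, compound 4, `C[C@@H](C(=O)NC[C@@H](COC(=O)C(C)(C)C)Cc1ccccc1)c1ccc(NS(C)(=O)=O)c(F)c1`, has not yet been measured. Its relation to compound 2 is the two compounds have the same atoms and bonds and differ only in configuration as drawn: 1 of 2 stereo elements differ; a stereocentre at a saturated chain carbon is drawn R in compound 2 and S in compound 4. Among the compounds with values here, no pair of measured compounds differs in configuration alone, so nothing in the numbers so far says how large a change of configuration at this chain carbon produces in this assay.

The configuration is changed at a stereocentre next to nothing that the data describe further; the step is therefore judged from the structural change alone. The expectation is that inverting this centre gives a weaker inhibitor, with the step from compound 2 to compound 4 estimated as a 2.3-fold higher number from compound 2 to compound 4 (0.37 log units; beyond the scatter), while a result within the scatter cannot be excluded. Compound 4 is expected to give about 700 nM in this assay, in the range 200 nM to 2500 nM.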

Compound 4, inhibition constant: 370 nM
The estimate for compound 4 lay 1.9-fold (0.28 log units) above the measured number; the range from low to high includes it.
By their numbers in this assay, from the lowest: compounds 2, 1, 4 and 3 (each within the scatter of the next).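

In this assay, within the data shown here, the inversion at the saturated chain carbon gives a 1.2-fold higher number from compound 2 to compound 4 (0.09 log units; within the scatter) and is the first reading of a change of configuration alone. The two drawn configurations at this carbon are therefore not told apart in this assay when the rest of the structure is that of compound 2. The step can be assigned to this stereocentre and to nothing else: the fact that compounds 2 and 4 differ only in the configuration as drawn.

On these data alone, the second stereocentre is drawn the same way in compound 2 and compound 4, so its configuration remains open, as does whether the inversion would stay this small with the substituted benzyl group of compound 1 in place of the unsubstituted one. Also open, as far as these compounds go, is how this assay responds when a carboxylic acid or an amine replaces the ester.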